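This account rests on a few compounds, and the source may have more. Where it says the series, first, only, none or still open, it means among the compounds named here.

Measured compounds:

Compound 1, `Cc1nnc(SCC(=O)c2ccccc2)n1N1C(=O)c2ccccc2C1=O`. In a functional assay on A549 cells (Homo sapiens) for cytotoxicity, read by MTT assay, with a stated time of 48 h (a lower number here means a stronger inhibitor, a higher number a weaker inhibitor), compound 1 gives > 200000 nM, which is a limit of the assay and not a number.
Compound 2, `C=CCSc1nnc(-c2cc(OC)c(OC)c(OC)c2)n1N1C(=O)c2ccccc2C1=O`. Compound 2 gives > 200000 nM, again a limit of the assay.
Compound 3, `COc1cc(-c2nnc(SCC(=O)c3ccc(C)cc3)n2N2C(=O)c3ccccc3C2=O)cc(OC)c1OC`. Compound 3 gives 6760 nM.

Going by the values given here, compound 3 thus holds the only number in this assay; the other two values sit at the limit of > 200000 nM in this assay, at which 2 of the 3 values shown sit. Among the compounds with values here, the one measured step, an at least 29-fold lower number from compound 2 to compound 3 (1.47 log units; beyond the scatter), is large and concerns the group on the saturated chain carbon bound to sulfur, not the aromatic ring.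

Compound 4, `COc1cc(-c2nnc(SCC(=O)c3ccccc3)n2N2C(=O)c3ccccc3C2=O)cc(OC)c1OC`, differs from compound 3 by hydrogen in place of methyl on an aromatic carbon. Within the data shown here, no measured step touches this place: the step from compound 2 to compound 3 changes a different part of the molecule, and compounds 1 and 2 give limits only. On that basis no shift beyond the scatter is expected, and the step of a 1.2-fold higher number from compound 3 to compound 4 (0.07 log units; within the scatter) is estimated as small. Compound 4 is therefore expected to give about 8000 nM in this assay, within a range of 2500 nM to 30000 nM.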

Compound 4, half-maximal inhibitory concentration: > 200000 nM
Compound 4 ended at the assay's limit; the forecaster's own chance of this, stated with the estimate: 10%; middle value at least 25-fold (1.39 log units) from the limit.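

In this assay, the change from 4-methylphenyl to phenyl gives an at least 29-fold higher number from compound 3 to compound 4 (1.47 log units; beyond the scatter), so this one methyl, on an aromatic carbon para to a large group, decides whether the series gives a readable number here. The earlier step concerned the whole group on the saturated chain carbon bound to sulfur, whereas this one shows that a single-carbon change at the far end of that group is also large, though the finding rests on this one pair. The steps from compound 1 and from compound 2 to compound 4 cannot be read, and compound 3 stays the only compound with a number: the limit of > 200000 nM in this assay, at which 3 of the 4 values shown sit.

Open, as far as these compounds go, is whether an ethyl, a methoxy or a chloro group on that same aromatic carbon would also give a readable number. Equally open, from the compounds shown here alone, is whether the 4-methylphenyl group would still give one with methyl in place of the 3,4,5-trimethoxyphenyl group.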